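The source may hold more compounds than are shown below. What is called first, only, known or untested is meant among the compounds shown, and "the series" means these compounds.

Measured so far in an assay on isolated protein for inhibition of Maltase-glucoamylase (Homo sapiens), with a stated time of 15 min; a lower number here means a stronger inhibitor, a higher number a weaker inhibitor:
compound 1 `O=C(N/N=C/c1cccnc1)c1ccc(-c2nc3ccccc3s2)cc1` — "not active" (no number reported)
compound 2 `O=C(N/N=C/c1ccc(O)c(O)c1)c1ccc(-c2nc3ccccc3s2)cc1` — 15100 nM
compound 3 `COc1ccc(/C=N/NC(=O)c2ccc(-c3nc4ccccc4s3)cc2)cc1OC` — "not active" (no number reported)

The three compounds share one core and differ only in the aryl group attached to the carbon that carries the double bond to nitrogen. Compound 1 gave no number in this assay and was reported as "not active" (no number reported); the same was reported for compound 3, so neither sets a reference value. Only compound 2 gave a measurable half-maximal inhibitory concentration, 15100 nM, which is a weak result in absolute terms. Compound 1 therefore stands without a number of its own, alongside one other entry in the same position, and below compound 2 in measurable activity.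

Compound 4 `O=C(N/N=C/c1ccc([N+](=O)[O-])cc1)c1ccc(-c2nc3ccccc3s2)cc1` has not been measured. It differs from compound 1 in one place: 4-nitrophenyl in place of pyridin-3-yl on a carbon with a double bond to nitrogen. Going by the values given here, no measured pair in this set isolates this particular exchange, so the size and direction of the step cannot be read from the data. Given that compound 1 gave "not active" (no number reported) and that compound 3 gave "not active" (no number reported), while only compound 2 with its 15100 nM produced a number, the expectation for compound 4 is at best weak inhibition, and quite possibly another entry without a number. The estimate for compound 4 in this assay is 30000 nM, with a range from 8000 nM to 120000 nM.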

Compound 4, half-maximal inhibitory concentration: 26400 nM
The estimate for compound 4 lay 1.1-fold (0.06 log units) above the measured number, within the range that was stated.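

Compound 4 is the second compound to give a number in this assay, so a measurable result at this position is no longer tied to the 3,4-dihydroxyphenyl group of compound 2. Exchanging that group for 4-nitrophenyl gives a 1.7-fold higher number from compound 2 to compound 4 (0.24 log units; within the scatter), and this assay therefore does not separate the two groups. A hydroxyl-bearing ring is thus not needed for a number here, although the result does not extend to every aryl group: compound 1, with pyridin-3-yl, gave "not active" (no number reported) in this assay, and compound 3 gave "not active" (no number reported) there as well. The data shown offer no evidence that bears on the reason for this outcome.

What these compounds leave open is whether an amino group or a carboxylic acid in place of the nitro group of compound 4 would still give a number. From the compounds shown here alone, it is also open whether a phenyl ring carrying a single hydroxyl would do so, and whether any group at this position can bring the shared core beyond the weak level seen so far.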